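This account rests on a few compounds, and the source may have more. Where it says the series, first, only, none or still open, it means among the compounds named here.

Measured so far:
Compound 1 `O=C(CN(c1nc(Cl)nc2[nH]cnc12)C1CC1)N[C@@H](CO)C(=O)OCc1ccccc1`: 34.2%
Compound 2 `O=C(CN(c1nc(Cl)nc2[nH]cnc12)C1CC1)N[C@@H](CC(=O)OCc1ccccc1)C(=O)OCc1ccccc1`: 22.4%

Both were tested in a functional assay on the whole organism (Tail, strain ICR) with Mus musculus as the target, in the tail flick test, with a stated time of 60 min, at a dose of 25 umol/kg by the oral route; on this read-out higher numbers stand for a stronger effect at the one dose given and lower numbers for a weaker effect. On these two numbers compound 2 stands lowest; its nearest neighbour, compound 1, lies higher by the amount shown in the single step known here, a number 11.8 percentage points lower from compound 1 to compound 2 (beyond the scatter), a modest change beyond the scatter.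

The new compound 3 `CSCC[C@H](NC(=O)CN(c1nc(Cl)nc2[nH]cnc12)C1CC1)C(=O)OCc1ccccc1` is reached from compound 2 by one change:

(methylsulfanyl)methyl in place of benzyloxycarbonyl on a saturated chain carbon, two bonds along the chain from an amide-type nitrogen and a carbonyl carbon

Within the data shown here, no measured step covers this exact change. Among the measured compounds shown here, the one step known, a number 11.8 percentage points lower from compound 1 to compound 2 (beyond the scatter), concerns the same position but a different pair of groups, so it bears only loosely on the new case. Given that compound 2 sits lowest and that leaving the benzyloxycarbonyl reverses the group that went with the drop, a small rise is expected for compound 3, a number 7.6 percentage points higher from compound 2 to compound 3 (within the scatter), though a step within the scatter would not be surprising. Compound 3 is estimated at 30%, within 15% to 45%.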

Compound 3, a percentage reported as activity, at one dose (the size of the read-out at that dose, not a potency): 30.8%
Compound 3: middle estimate off by 0.8 percentage points, on the low side; measured number inside the range.
By their numbers in this assay, from the lowest: compounds 2, 3 and 1 (each within the scatter of the next, the first and the last beyond it).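

Swapping the benzyloxycarbonyl, with its 10 heavy atoms and aromatic ring, for the ring-free (methylsulfanyl)methyl with 3 heavy atoms gives a number 8.4 percentage points higher from compound 2 to compound 3 (within the scatter) in this assay and so does not move the effect clear of the scatter, even though the group shrinks greatly. Against the hydroxy group, the same (methylsulfanyl)methyl gives a number 3.4 percentage points lower from compound 1 to compound 3 (within the scatter) and so cannot be told apart from it at this place, which leaves compound 3 within the scatter of both compound 1 and compound 2, although those two lie beyond the scatter of each other. Nothing measured here explains these numbers.

The compounds shown leave open how an amine, a carboxylic acid or a longer plain carbon chain would read at this place. A single dose also leaves open how potency compares across the series.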